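Bromo for methyl on the anilino ring of compound 1

The source may report more compounds than this note shows. Statements on the series, on what has been measured and on what is new or still open speak of the compounds shown alone.

Measured so far in a functional assay on MGC-803 cells (Homo sapiens) for inhibition, read by sulforhodamine B assay; on this read-out higher numbers stand for weaker inhibition and lower numbers for stronger inhibition:
- compound 1, `Cc1ccc(NC2=CC(=O)c3nc4n(c3C2=O)[C@H]2OC[C@@H](O)[C@H]2OC4)cc1`: 1420 nM
- compound 2, `O=C1C(NC2CC2)=CC(=O)c2c1nc1n2[C@H]2OC[C@@H](O)[C@H]2OC1`: > 4000 nM (a limit)
- compound 3, `O=C1C(Nc2ccccc2)=CC(=O)c2c1nc1n2[C@H]2OC[C@@H](O)[C@H]2OC1`: 1830 nM

Compound 1 has the lowest number of the two numbers given, but compound 3 sits within the scatter of it, so no order between the two is claimed. Compound 2 reports only a limit of this assay, > 4000 nM. Within the data shown here, the one step that can be read is an at least 2.1-fold lower number from compound 2 to compound 3 (0.33 log units; beyond the scatter), and it concerns only (the limit of > 4000 nM in this assay, at which 1 of the 3 values shown sits).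

Compound 4, `O=C1C=C(Nc2ccc(Br)cc2)C(=O)c2c1nc1n2[C@H]2OC[C@@H](O)[C@H]2OC1`, differs from compound 1 by bromo in place of methyl on an aromatic carbon. Among the measured compounds shown here, no measured step changes a substituent on the aromatic ring of the amine; the only step in hand swaps the whole group on the amine nitrogen, which says nothing about a bromo in place of a methyl. The expected step is therefore a 1.1-fold lower number from compound 1 to compound 4 (0.04 log units; within the scatter), within the scatter. Compound 4 is expected near 1300 nM, between 500 nM and 3500 nM.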

Compound 4, half-maximal inhibitory concentration: 1010 nM
Beside the measured number, compound 4's estimate is 1.3-fold (0.11 log units) above it; low and high end bracket the measured number.
By their numbers in this assay, from the lowest: compounds 4, 1 and 3 (each within the scatter of the next). At a limit, above all of these: compound 2.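

In this assay, among these compounds, the change from 4-methylphenyl to 4-bromophenyl gives a 1.4-fold lower number from compound 1 to compound 4 (0.15 log units; within the scatter) and is the first reading of a substituent swap on this aromatic ring, as the earlier step replaced the whole group on the amine nitrogen. At this carbon, para to a large group, methyl and bromo therefore cannot be told apart in this assay, and the series gains no order between them. No measured property in the notes bears on this change.

The two groups compared here leave open whether a different kind of substituent at this carbon, such as an amine, a carboxylic acid or a longer chain, would move the number beyond the scatter. Substitution on the other carbons of this ring also remains open.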